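Trifluoromethyl for fluoro on the methylated core

A few compounds are considered here, and "the series" means these few. Any claim that something is new, unique, unknown or untested is made for them only; others in the source may bear on it.

Of the compounds shown here, three have been measured in a functional assay on A2780 cells (Homo sapiens) for inhibition, read by sulforhodamine B assay; on this read-out lower numbers stand for stronger inhibition of growth and higher numbers for weaker inhibition of growth. Compound 1 `Fc1ccc(-c2ccc(-c3ccc(-c4nc5ccccc5[nH]4)cc3)cc2)cc1` gives 48200 nM in this assay. Compound 2 `FC(F)(F)c1ccc(-c2ccc(-c3ccc(-c4nc5ccccc5[nH]4)cc3)cc2)cc1` gives 100000 nM in this assay. Compound 3 `Cc1ccc2[nH]c(-c3ccc(-c4ccc(-c5ccc(F)cc5)cc4)cc3)nc2c1` gives 24600 nM in this assay.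

Compound 2 differs from compound 1 by trifluoromethyl in place of fluoro on an aromatic carbon and this change produced a 2.1-fold higher number from compound 1 to compound 2 (0.32 log units; beyond the scatter). Compound 3 differs from compound 1 by methyl in place of hydrogen on an aromatic carbon, which gave a 2.0-fold lower number from compound 1 to compound 3 (0.29 log units; within the scatter); the two values lie within the scatter of each other. Compound 2 sits beyond the scatter from compound 3, as their two values show.

Compound 4 `Cc1ccc2[nH]c(-c3ccc(-c4ccc(-c5ccc(C(F)(F)F)cc5)cc4)cc3)nc2c1` has not been measured. It differs from compound 3 by trifluoromethyl in place of fluoro on an aromatic carbon. This is the same change already seen from compound 1 to compound 2, and the place on the ring is described in the same words for both pairs, so the same kind of step is expected. On the core of compound 3 the estimated step is a 2.1-fold higher number from compound 3 to compound 4 (0.33 log units; beyond the scatter), which rests on the outcome of a 2.1-fold higher number from compound 1 to compound 2 (0.32 log units; beyond the scatter) transferred to compound 3. Among the compounds with values here, with only one measured instance of the change, the uncertainty is wide. Compound 4 is therefore expected to give about 52000 nM in this assay, with a range estimated from 25000 nM to 100000 nM.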

Compound 4, concentration for 50% growth inhibition: 12300 nM
Compound 4: middle estimate off by 4.2-fold (0.63 log units), on the high side, outside the stated range (below it).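

In this assay, trifluoromethyl in place of fluoro did not carry over from one core to the other; on the methylated core the step reads a 2.0-fold lower number from compound 3 to compound 4 (0.30 log units; within the scatter), so compound 3 and compound 4 are not separated, and the comparison with the earlier step shows a real gap: the same change on two cores in this assay, a 2.1-fold higher number (0.32 log units; beyond the scatter) from compound 1 to compound 2 and a 2.0-fold lower number (0.30 log units; within the scatter) from compound 3 to compound 4, 4.1-fold (0.62 log units) apart, beyond the scatter of two such steps. Methyl in place of hydrogen likewise depends on its partner group, with an 8.1-fold lower number from compound 2 to compound 4 (0.91 log units; beyond the scatter) on the trifluoromethyl side, a larger step than the one on the fluoro side: the same change on two cores in this assay, a 2.0-fold lower number (0.29 log units; within the scatter) from compound 1 to compound 3 and an 8.1-fold lower number (0.91 log units; beyond the scatter) from compound 2 to compound 4, 4.1-fold (0.62 log units) apart, beyond the scatter of two such steps. Both comparisons rest on the same four compounds, so they are one observation read in two directions: they show that neither step can be assumed to transfer between these two cores, but they give no cause and no rule for any other core or group.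

Still open, going by these compounds, is whether a chloro, a methoxy or an amine in the place of fluoro would track the step seen on the core of compound 1 or the one seen on the core of compound 3. Equally open, on these data alone, is whether an ethyl or a carboxylic acid in the place of the methyl would show the same dependence on the group at the far end of the molecule.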